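The source may hold more compounds than are shown below. What is called first, only, known or untested is meant among the compounds shown, and "the series" means these compounds.

Compound 1, `ClCc1ccc(Cn2cnc3c(Cl)ncnc32)cc1`, and compound 3, `ClCc1ccc(Cn2cnc3c(Cl)nc(Cl)nc32)cc1`, share a core and differ in a single place, described as chloro in place of hydrogen on an aromatic carbon. In a functional assay on NCI-H226 cells (Homo sapiens) for cytotoxicity, read by sulforhodamine B assay, with a stated time of 48 h (on this read-out lower numbers stand for stronger inhibition of growth and higher numbers for weaker inhibition of growth), compound 1 gives 7410 nM, and compound 3 gives 9550 nM; the step between them, a 1.3-fold higher number from compound 1 to compound 3 (0.11 log units; within the scatter), is small enough that the two numbers cannot be told apart. Compound 2, `ClCc1ccccc1Cn1cnc2ncnc(Cl)c21`, is built from the same atoms as compound 1 joined differently; how the two cores differ is not broken down here. In this assay compound 2 gives 7940 nM, which sits close to the numbers for compound 1 and compound 3, with all three values inside the scatter of one another.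

Compound 4, `ClCc1ccccc1Cn1cnc2nc(Cl)nc(Cl)c21`, has not been measured. Among the compounds with values here, it differs from compound 2 by chloro in place of hydrogen on an aromatic carbon, the same change as the one from compound 1 to compound 3, at a place described in the same words. Because the earlier step of a 1.3-fold higher number from compound 1 to compound 3 (0.11 log units; within the scatter) stayed within the scatter, the step from compound 2 to compound 4 in this assay is expected to be similarly small, about a 1.2-fold higher number from compound 2 to compound 4 (0.09 log units; within the scatter). Compound 4 is therefore estimated at 9800 nM, with a likely range from 5000 nM to 19000 nM.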

Compound 4, concentration for total growth inhibition: 6760 nM
Estimate against measurement, compound 4: 1.4-fold (0.16 log units) above; the range from low to high includes it.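

In this assay, the new step, a 1.2-fold lower number from compound 2 to compound 4 (0.07 log units; within the scatter), stays within the scatter, so chloro in place of hydrogen on an aromatic carbon leaves compound 2 and compound 4 indistinguishable, as it did on the core of compound 1. Set side by side, the two steps do not differ: the same change on two cores in this assay, a 1.3-fold higher number (0.11 log units; within the scatter) from compound 1 to compound 3 and a 1.2-fold lower number (0.07 log units; within the scatter) from compound 2 to compound 4, 1.5-fold (0.18 log units) apart, within the scatter of two such steps. This shows that, across these two pairs, the change carried over from one core to the other as a step too small to read, but it does not show that the change would stay this small on any other core, and the opposite directions of the two printed steps cannot be read as a real difference.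

The compounds shown leave open whether another group at the same place, such as an amine or a methoxy group, would give a step beyond the scatter. They also leave open whether the same change stays this small on a core carrying a longer chain in place of the chloromethyl group.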